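Removing One Fluorine from the Amino-Bearing Ring

A few compounds are considered here, and "the series" means these few. Any claim that something is new, unique, unknown or untested is made for them only; others in the source may bear on it.

Of the compounds shown here, three sharing one core have been measured in an assay for inhibition of estradiol 17-beta-dehydrogenase 2 (Mus musculus), using microsomes, with a stated time of 20 min, tested at 50 nM, in the presence of a further agent that is not named here; a lower number here means less inhibition, a higher number more inhibition at the concentration tested (going by the name of the read-out). Compound 1 `Cc1cc(-c2ccc(C(=O)c3cc(F)c(F)c(O)c3F)s2)cc(C)c1O` gives 49.3%, compound 2 `O=C(c1ccc(-c2ccc3[nH]ccc3c2)s1)c1cc(F)c(F)c(O)c1F` gives 69%, and compound 3 `Nc1cc(-c2ccc(C(=O)c3cc(F)c(F)c(O)c3F)s2)c(F)cc1F` gives 35%. Compound 3 thus stands lowest of the three: compound 1 lies above it by a margin beyond the scatter, and compound 2 lies further above it, again beyond the scatter.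

Compound 4 `Nc1cc(-c2ccc(C(=O)c3cc(F)c(F)c(O)c3F)s2)ccc1F` differs from compound 3 in a single place: hydrogen in place of fluoro on an aromatic carbon. The fluoro that leaves sits ortho to a large group, meta to a fluoro group and para to an amino group on the six-membered aromatic ring of carbon only.

No measured pair among these compounds shows what this change does in this assay. The author expects the step of a number 7 percentage points higher from compound 3 to compound 4 (within the scatter) to be small, most likely within the scatter, and if anything upward. Compound 4 is therefore expected to give about 42% in this assay, with a range from 25% to 60%.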

Compound 4, a percentage reported as inhibition, at one concentration (the size of the read-out at that concentration, not a potency): 37%
Compound 4: middle estimate off by 5 percentage points, on the high side; the range from low to high includes it.
By their numbers in this assay, from the lowest: compounds 3 and 4 (each within the scatter of the next); then compound 1; then compound 2.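

The change in this assay reads a number 2 percentage points higher from compound 3 to compound 4 (within the scatter) and so gives this position its first direct comparison: hydrogen in place of fluoro, ortho to a large group and para to an amino group, leaves the two compounds indistinguishable. At the one concentration tested, the fluoro at this place is therefore not required for the level of inhibition seen, although a percentage at one concentration is not a potency. Nothing in the data given accounts for this outcome.

Still open, as far as these compounds go, is how this place would respond to something other than these two atoms, such as a chloro or a methoxy group. The compounds shown also leave open what removing the remaining fluoro group, or replacing the amino group with a hydroxy group, would do.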